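Removing a Chloro from a Weak Sulfonamide Analogue

The source may hold more compounds than are shown below. What is called first, only, known or untested is meant among the compounds shown, and "the series" means these compounds.

Compound 1 `CCCn1c(=O)[nH]c2nc(-c3ccc(S(=O)(=O)N(C)C)cc3)[nH]c2c1=O` carries a small sulfonamide substituent on the shared core, and in an assay on CHO cells for displacement of a labelled ligand from adenosine receptor A1 (Homo sapiens), read by scintillation counting, with a stated time of 90 min, in the presence of a further agent that is not named here (a higher number here means a weaker inhibitor, a lower number a stronger inhibitor), compound 1 gives 190 nM. Compound 2 `CCCn1c(=O)[nH]c2nc(-c3ccc(S(=O)(=O)N4CCN(c5cccc(Cl)c5)CC4)cc3)[nH]c2c1=O` carries a much larger sulfonamide substituent ending in a 3-chlorophenyl group. In this assay compound 2 reaches only the limit of the assay, > 1000 nM, and that limit is all that is known of where it stands (the limit of > 1000 nM in this assay, at which 1 of the 2 values shown sits). Compound 3 `CCCn1c(=O)[nH]c2nc(-c3ccc(S(=O)(=O)N4CCN(c5ccccc5)CC4)cc3)[nH]c2c1=O` differs from compound 2 by one change: hydrogen in place of chloro on an aromatic carbon. That change is small against the rest of the structure, so the step from compound 2 to compound 3 is expected to stay within the scatter, a step that the limit leaves unreadable from compound 2 to compound 3. Compound 3 is therefore estimated at 2000 nM, expected between 700 nM and 8000 nM.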

Compound 3, inhibition constant: 364 nM
Estimate against measurement, compound 3: 5.5-fold (0.74 log units) above, and the stated range ends above it.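

Losing this one chloro from the 3-chlorophenyl group has a clear effect: in this assay, the change to hydrogen gives an at least 2.7-fold lower number from compound 2 to compound 3 (0.43 log units; beyond the scatter). With a plain phenyl at its end, the large sulfonamide substituent of compound 3 still yields a readable value, 364 nM. On these data alone, the true size of the step stays unknown, because compound 2 stands at a limit of the assay: the limit of > 1000 nM in this assay, at which 1 of the 3 values shown sits. As far as these compounds go, whether a fluoro or a methoxy group in the same place would behave more like chloro or like hydrogen remains open.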